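The compounds below may be only part of what the source reports. "The series", "measured", "known", "first", "only" and "open" are said of these compounds alone.

Measured so far:
compound 1, `N#Cc1ccc(C(Nc2ccc(C(=O)O)cc2)c2ccc3cccnc3c2O)cc1`: 16000 nM
compound 2, `O=C(O)c1ccc(NC(c2ccc(Br)cc2)c2ccc3cccnc3c2O)cc1`: 6700 nM
compound 3, `O=C(O)c1ccc(NC(c2ccccn2)c2ccc3cccnc3c2O)cc1`: 38000 nM

All three were tested in an assay on isolated protein for inhibition of CAAX prenyl protease 2 (Homo sapiens), with stated times of 60 s and 60 min; on this read-out higher numbers stand for weaker inhibition and lower numbers for stronger inhibition. Compound 3 gives the highest number of the three, as shown by the steps of a 2.4-fold higher number from compound 1 to compound 3 (0.38 log units; beyond the scatter) and a 5.7-fold higher number from compound 2 to compound 3 (0.75 log units; beyond the scatter). Compound 4, `O=C(O)c1ccc(NC(c2cccnc2)c2ccc3cccnc3c2O)cc1`, differs from compound 3 only in the ring carried on the saturated chain carbon: pyridin-3-yl in place of pyridin-2-yl on a saturated chain carbon bound to an aromatic carbon and a nitrogen on an aromatic ring. Within the data shown here, no measured step swaps one pyridyl ring for another, so none bears on this change directly; the two steps into compound 3 show only that the pyridin-2-yl ring gave weaker inhibition than either substituted phenyl ring. Compound 4 is therefore expected to stay near compound 3, with the step of a 1.4-fold lower number from compound 3 to compound 4 (0.13 log units; within the scatter) expected to lie within the scatter. The estimate for compound 4 is 28000 nM, in the range 9000 nM to 90000 nM.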

Compound 4, half-maximal inhibitory concentration: 14000 nM
Compound 4: middle estimate off by 2.0-fold (0.30 log units), on the high side, within the range that was stated.
By their numbers in this assay, from the lowest: compound 2; then compounds 4 and 1 (each within the scatter of the next); then compound 3.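

Swapping pyridin-2-yl for pyridin-3-yl changes no atom count, yet it is enough to matter on this saturated chain carbon: this assay shows a 2.7-fold lower number from compound 3 to compound 4 (0.43 log units; beyond the scatter) for that swap. The pyridin-3-yl ring stands level with 4-cyanophenyl, at a 1.1-fold lower number from compound 1 to compound 4 (0.06 log units; within the scatter), while 4-bromophenyl still gives stronger inhibition, at a 2.1-fold higher number from compound 2 to compound 4 (0.32 log units; beyond the scatter). Nothing available explains why the two pyridyl rings differ. Still open, as far as these compounds go, is how pyridin-4-yl, or a pyridin-3-yl ring carrying an amine, would behave on this carbon.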